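The source may hold more compounds than are shown below. What is called first, only, known or untested is meant among the compounds shown, and "the series" means these compounds.

Working notes on the series, read in a functional assay on A2780 cells (Homo sapiens) for inhibition, read by sulforhodamine B assay; a lower number here means a stronger inhibitor of growth, a higher number a weaker inhibitor of growth. Compound 3 (`Cc1ccc2[nH]c(-c3ccc(-c4ccc(-c5ccc(F)cc5)cc4)cc3)nc2c1`) gives 24600 nM, the highest number of the three measured, while compound 1 (`Cc1ccc2[nH]c(-c3ccc(-c4ccc(-c5cccc(Cl)c5)cc4)cc3)nc2c1`) gives 2800 nM and compound 2 (`COc1ccc(-c2ccc(-c3ccc(-c4nc5cc(C)ccc5[nH]4)cc3)cc2)cc1OC`) gives 2130 nM. Compound 4 (`Cc1ccc2[nH]c(-c3ccc(-c4ccc(-c5ccc(C(F)(F)F)cc5)cc4)cc3)nc2c1`) carries trifluoromethyl in place of fluoro on an aromatic carbon, para to a large group: trifluoromethyl in place of fluoro on an aromatic carbon. Going by the values given here, no measured step makes this exact change. The closest evidence is replacement of the whole 4-fluorophenyl: an 8.8-fold higher number from compound 1 to compound 3 (0.94 log units; beyond the scatter) and a 12-fold higher number from compound 2 to compound 3 (1.06 log units; beyond the scatter), whereas a 1.3-fold lower number from compound 1 to compound 2 (0.12 log units; within the scatter). Compound 3 thus stands apart, so a modest move to a lower number is expected, with wide uncertainty. The expected step is a 3.1-fold lower number from compound 3 to compound 4 (0.49 log units; beyond the scatter). For compound 4 the estimated value is 8000 nM, with an expected range of 2000 nM to 28000 nM.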

Compound 4, concentration for 50% growth inhibition: 12300 nM
Beside the measured number, compound 4's estimate is 1.5-fold (0.19 log units) below it, and the stated range covers the measured number.
By their numbers in this assay, from the lowest: compounds 2 and 1 (each within the scatter of the next); then compounds 4 and 3 (each within the scatter of the next).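

At this position, para to a large group, trifluoromethyl in place of fluoro gives a 2.0-fold lower number from compound 3 to compound 4 (0.30 log units; within the scatter) in this assay, so this exchange does not separate the two compounds. The 4-(trifluoromethyl)phenyl group also stays apart from the other two aryl groups, with a 5.8-fold higher number from compound 2 to compound 4 (0.76 log units; beyond the scatter) and a 4.4-fold higher number from compound 1 to compound 4 (0.64 log units; beyond the scatter). Nothing available explains these steps.

Still open, going by these compounds, is whether the gap to compounds 1 and 2 goes with the place of the groups or with the groups themselves. On these data alone, how an amine or a carboxylic acid would read at this position is also open.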